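Antiproliferative series: benzyloxy variation on the shared core

The compounds below may be only part of what the source reports. "The series", "measured", "known", "first", "only" and "open" are said of these compounds alone.

Measured compounds in a functional assay on U-251 cells (Homo sapiens) for antiproliferative activity, read by MTT assay, with a stated time of 24 h; a higher number here means a weaker inhibitor, a lower number a stronger inhibitor:
- compound 1 `COc1ccc2c(=O)c(-c3cc(OC)c(OC)cc3OC)coc2c1`: 9400 nM
- compound 2 `COc1cccc(C(=O)Oc2ccc3c(=O)c(-c4cc(OC)c(OC)cc4OC)coc3c2)c1`: > 10000 nM (a limit of the assay, not a number)
- compound 3 `COc1cc(OC)c(-c2coc3cc(OCc4ccc(F)cc4)ccc3c2=O)cc1OC`: 3200 nM

Compound 3 gives the lowest of the two numbers available; its nearest neighbour is compound 1, and the step of a 2.9-fold lower number from compound 1 to compound 3 (0.47 log units; beyond the scatter) is beyond the scatter. Compound 2 sits at the limit (the limit of > 10000 nM in this assay, at which 1 of the 3 values shown sits), so the step of an at least 1.0-fold higher number from compound 1 to compound 2 (0.02 log units; that floor lies within the scatter) is only a floor, and an at least 3.1-fold lower number from compound 2 to compound 3 (0.49 log units; beyond the scatter) is likewise a floor.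

Compound 4 `COc1cc(OC)c(-c2coc3cc(OCc4ccccc4C#N)ccc3c2=O)cc1OC` is not yet measured. Its difference from compound 3 is 2-cyanophenyl in place of 4-fluorophenyl on a saturated chain carbon bound to an oxygen on an aromatic ring. For the measured compounds named here, no measured step alters the aryl substituent of the benzyloxy group: a 2.9-fold lower number from compound 1 to compound 3 (0.47 log units; beyond the scatter) compares a benzyl group with hydrogen, and an at least 3.1-fold lower number from compound 2 to compound 3 (0.49 log units; beyond the scatter) compares a benzyl with an aryl carbonyl. Going by the values given here, the step from compound 3 to compound 4 therefore has no direct precedent, and no change beyond the scatter is expected in this assay. Compound 4 is estimated at 3500 nM, within 1200 nM to 10000 nM, the expected step being a 1.1-fold higher number from compound 3 to compound 4 (0.04 log units; within the scatter).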

Compound 4, half-maximal inhibitory concentration: 980 nM
For compound 4 the middle estimate is 3.6-fold (0.55 log units) above the measured one; measured number below the stated range.
By their numbers in this assay, from the lowest: compound 4; then compound 3; then compound 1. At a limit, above all of these: compound 2.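

In this assay, the aryl group on the saturated chain carbon bound to an oxygen on an aromatic ring now proves to matter in its own right: 2-cyanophenyl in place of 4-fluorophenyl gives a 3.3-fold lower number from compound 3 to compound 4 (0.51 log units; beyond the scatter). Earlier steps compared the benzyl group only with hydrogen or an aryl carbonyl, and with 2-cyanophenyl the comparison with hydrogen widens to a 9.6-fold lower number from compound 1 to compound 4 (0.98 log units; beyond the scatter). The step of an at least 10-fold lower number from compound 2 to compound 4 (1.00 log units; beyond the scatter) is only a floor, as compound 2 stands at a limit: the limit of > 10000 nM in this assay, at which 1 of the 4 values shown sits.

A single aryl change cannot separate the loss of the fluorine from the entry of the nitrile. From the compounds shown here alone, how an unsubstituted phenyl, or an aryl group carrying an amine or a carboxylic acid in place of the nitrile, would compare remains open.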